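Trifluoromethoxy for Fluoro on a Compound Already at the Limit

This account rests on a few compounds, and the source may have more. Where it says the series, first, only, none or still open, it means among the compounds named here.

Compound 1 `Cc1ccc2nc(-c3ccccc3F)[nH]c(=O)c2c1` and compound 2 `Cc1ccc2c(=O)[nH]c(-c3cccc(F)c3)nc2c1` are built from the same atoms joined differently; the difference between the two cores is not broken down here. In a functional assay on HCT-15 cells (Homo sapiens) for cytotoxicity, read by MTT assay, with a stated time of 2 days (a lower number here means a stronger inhibitor, a higher number a weaker inhibitor), compound 1 gives only a limit, > 50000 nM. Compound 2 gives 14400 nM in this assay. Compound 3 `Cc1ccc2c(=O)[nH]c(-c3cccc(OC(F)(F)F)c3)nc2c1` carries trifluoromethoxy in place of fluoro on an aromatic carbon relative to compound 2. In this assay compound 3 likewise gives only a limit, > 50000 nM. This makes the step of an at least 3.4-fold higher number from compound 2 to compound 3 (0.54 log units; beyond the scatter), a weakening that sits on (the limit of > 50000 nM in this assay, at which 2 of the 3 values shown sit). Compound 4 `Cc1ccc2nc(-c3ccccc3OC(F)(F)F)[nH]c(=O)c2c1` differs from compound 1 by the same kind of change, (trifluoromethoxy in place of fluoro on an aromatic carbon), the group here sitting ortho to a large group rather than meta to a large group. Compound 1 already sits at the limit in this assay with > 50000 nM. Compound 4 is therefore expected to stay at that limit, with an expected step that the limit leaves unreadable from compound 1 to compound 4. The estimate for compound 4 is 100000 nM.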

Compound 4, half-maximal inhibitory concentration: 2790 nM
Beside the measured number, compound 4's estimate is 36-fold (1.55 log units) above it; measured number below the stated range.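

In this assay the swap gives an at least 17-fold lower number from compound 1 to compound 4 (1.25 log units; beyond the scatter) on the core of compound 1, so here trifluoromethoxy in place of fluoro goes with a much stronger result. The same change therefore does not carry its direction from one core to the other: the same change on two cores in this assay, an at least 3.4-fold higher number (0.54 log units; beyond the scatter) from compound 2 to compound 3 and an at least 17-fold lower number (1.25 log units; beyond the scatter) from compound 1 to compound 4, at least 62-fold (1.79 log units) apart, beyond the scatter of two such steps
What this does not show is whether the core or the place of the group decides the direction, and the true size of each step stays unknown: the limit of > 50000 nM in this assay, at which 2 of the 4 values shown sit.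

The compounds shown leave open whether a smaller group in the same place, such as methoxy or an amine, would also give a lower number. They also leave open how trifluoromethoxy would behave ortho to a large group on the core of compound 2.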